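The source may report more compounds than this note shows. Statements on the series, on what has been measured and on what is new or still open speak of the compounds shown alone.

Working notes on the series. Compound 1 `O=[N+]([O-])c1cc(-c2nnc(-c3ccccc3)o2)cc(O)c1O`, compound 2 `O=[N+]([O-])c1cc(-c2nc(-c3ccccc3)no2)cc(O)c1O` and compound 3 `Cc1c(C)c(C)[n+]([O-])c(Cl)c1-c1noc(-c2cc(O)c(O)c([N+](=O)[O-])c2)n1` have been run in a functional assay on the whole organism (liver, strain Wistar) for inhibition, with Rattus norvegicus as the target, with a stated time of 3 h, at a dose of 3 mg/kg by the oral route; a lower number here means less inhibition, a higher number more inhibition at the dose given (going by the name of the read-out). In this assay compound 1 gives 67.8%, compound 2 gives 20.6% and compound 3 gives 7.9%. Compound 2 thus holds the second highest of the three numbers: compound 3 sits nearest, beyond the scatter below it, and compound 1 furthest, beyond the scatter above it. Compound 4 `O=[N+]([O-])c1cc(-c2nc(-c3ccc[n+]([O-])c3)no2)cc(O)c1O` is not yet measured. Relative to compound 2 it carries a group of 7 heavy atoms (5 carbon, 1 nitrogen, 1 oxygen; one six-membered aromatic ring with 1 hetero atom) in place of a group of 6 heavy atoms (6 carbon; one six-membered aromatic ring of carbon only), on an aromatic carbon. Within the data shown here, no step between measured compounds is available for this change; a small downward step, or none beyond the scatter, is expected, the step of a number 5.6 percentage points lower from compound 2 to compound 4 (within the scatter). In this assay compound 4 is estimated at 15%, in the range 3% to 33%.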

Compound 4, a percentage reported as inhibition, in the whole organism at one dose (the size of the read-out at that dose, not a potency): 77%
Estimate against measurement, compound 4: 62 percentage points below; measured number outside the range, above it.
By their numbers in this assay, from the lowest: compound 3; then compound 2; then compounds 1 and 4 (each within the scatter of the next).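

On an aromatic carbon of the five-membered aromatic ring, between two ring nitrogen atoms, the group carried matters strongly in this assay: the six-membered aromatic ring with 1 hetero atom in place of phenyl gives a number 56.4 percentage points higher from compound 2 to compound 4 (beyond the scatter). Among these compounds, this is the first step available at this position, and it shows that this single change can move the read-out by far more than the usual scatter. No measurement at hand accounts for the size of this step. The step rests on one pair of compounds. Going by these compounds, whether a phenyl carrying an amine or a carboxylic acid at this position would give a similar number stays open.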